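Extending the amine substituent of compound 3 toward compound 4

This account rests on a few compounds, and the source may have more. Where it says the series, first, only, none or still open, it means among the compounds named here.

Compound 1 `CCC(C)[C@H](NC[C@H]1CCCN1)c1cc(C(F)(F)F)ccc1N1CCN(C(=O)CCc2ccc(Cl)cc2Cl)CC1`: 110 nM
Compound 2 `CCC(C)[C@H](NC(C)=O)c1cc(C(F)(F)F)ccc1N1CCN(C(=O)CCc2ccc(Cl)cc2Cl)CC1`: 360 nM
Compound 3 `CN[C@@H](CC(C)C)c1cc(C(F)(F)F)ccc1N1CCN(C(=O)CCc2ccc(Cl)cc2Cl)CC1`: 1900 nM

In an assay on HEK293 cells for displacement of a labelled ligand from Melanocortin receptor 4 (Homo sapiens) (a lower number here means a stronger inhibitor, a higher number a weaker inhibitor), compound 3 stands at the weak end of this small set, giving 1900 nM. The step of a 5.3-fold higher number from compound 2 to compound 3 (0.72 log units; beyond the scatter) is modest, and the step of a 17-fold higher number from compound 1 to compound 3 (1.24 log units; beyond the scatter) is large, so compound 3 is the weakest of the three beyond the scatter.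

Compound 4 `COCCN[C@@H](CC(C)C)c1cc(C(F)(F)F)ccc1N1CCN(C(=O)CCc2ccc(Cl)cc2Cl)CC1` keeps everything of compound 3 except at the amine: methoxymethyl in place of hydrogen on a saturated chain carbon bound to an amine nitrogen. The amine thus carries a (2-methoxyethyl)amino group instead of methylamino.

Going by the values given here, two measured steps bear on it. Both compound 1 and compound 2 carry something larger than a methyl on that nitrogen, and both give lower numbers than compound 3, by a 17-fold higher number from compound 1 to compound 3 (1.24 log units; beyond the scatter) and a 5.3-fold higher number from compound 2 to compound 3 (0.72 log units; beyond the scatter). Compound 4 adds a chain with one acceptor but without the ring of compound 1, so a smaller gain than that of compound 1 seems likely, closer to the modest step seen with compound 2. The expected step is therefore a decrease in this assay of a 3.2-fold lower number from compound 3 to compound 4 (0.50 log units; beyond the scatter). Compound 4 is estimated at 600 nM, with a range from 200 nM to 1800 nM.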

Compound 4, inhibition constant: 620 nM
The estimate for compound 4 lay 1.0-fold (0.01 log units) below the measured number; the range from low to high includes it.
By their numbers in this assay, from the lowest: compound 1; then compounds 2 and 4 (each within the scatter of the next); then compound 3.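

In this assay, the change from methylamino to (2-methoxyethyl)amino gives a 3.1-fold lower number from compound 3 to compound 4 (0.49 log units; beyond the scatter). Of the steps that start from compound 3, this is the only one that leaves the 3-methylbutyl chain in place and alters only the group on the amine nitrogen, so this gain can be assigned to that group alone. The 2-methoxyethyl group brings the amine to the level of the acetamide, with a 1.7-fold higher number from compound 2 to compound 4 (0.24 log units; within the scatter) placing the two compounds within the usual scatter, while a 5.6-fold higher number from compound 1 to compound 4 (0.75 log units; beyond the scatter) leaves compound 1 clearly ahead. No supporting measurement is available to explain these differences.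

Whether the oxygen of the 2-methoxyethyl group matters, or chain length alone accounts for the gain, remains open, a question that a plain butyl chain on the same nitrogen could address. On these data alone, it is also open how the remaining step to compound 1 divides between its (pyrrolidin-2-yl)methyl group and its 2-methylbutyl chain, which a (pyrrolidin-2-yl)methyl group on the amine of compound 3 would help separate.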